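The source may hold more compounds than are shown below. What is called first, only, known or untested is meant among the compounds shown, and "the series" means these compounds.

Measured so far: compound 1 `O=C(Nc1cccc(-n2cc(-c3ccncc3)c(-c3cc(O)cc(Cl)c3)n2)c1)Nc1ccc(Cl)c(Cl)c1` with 79%; compound 2 `COc1cc(Cl)cc(-c2nn(-c3cccc(NC(=O)Nc4cc(C(F)(F)F)cc(C(F)(F)F)c4)c3)cc2-c2ccncc2)c1` with 22%.

In a functional assay on MDA-MB-435 cells (Homo sapiens) for inhibition, read by sulforhodamine B assay, with a stated time of 48 h, tested at 1 uM (a higher number here means a weaker effect of the compound at the concentration tested, a lower number a stronger effect), compound 1 gives 79%, the highest of the two numbers, and compound 2 sits far lower, beyond the usual scatter. Compound 3 `COc1cc(Cl)cc(-c2nn(-c3cccc(NC(=O)Nc4ccc(Cl)c(Cl)c4)c3)cc2-c2ccncc2)c1` is compound 1 with one change, (methyl in place of hydrogen on an oxygen on an aromatic ring), read one bond further out as hydroxy to methoxy. Within the data shown here, no measured pair isolates this change on its own; compound 2 carries the methoxy but differs elsewhere as well, so its number cannot be credited to the methyl alone. The expected step of a number 24 percentage points lower from compound 1 to compound 3 (beyond the scatter) is moderate and towards a stronger effect. Compound 3 is therefore expected to give about 55%, within 25% to 85%.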

Compound 3, a percentage reported as activity, at one concentration (the size of the read-out at that concentration, not a potency): 85%
Estimate against measurement, compound 3: 30 percentage points below; low and high end bracket the measured number.
By their numbers in this assay, from the lowest: compound 2; then compounds 1 and 3 (each within the scatter of the next).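

In this assay, replacing hydroxy with methoxy gives a number 6 percentage points higher from compound 1 to compound 3 (within the scatter), so this single change leaves the two compounds indistinguishable. On this core, the hydrogen on that oxygen can therefore be replaced by methyl without a measurable difference at this one concentration. Nothing available explains why the two compounds read alike.

On these data alone, whether a longer chain on that oxygen, such as ethyl, or an amine in place of the hydroxy would read the same remains open. So does whether the two compounds would still match at other concentrations.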